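Removing the acetoxy from a brominated lactone

The compounds below may be only part of what the source reports. "The series", "measured", "known", "first", "only" and "open" are said of these compounds alone.

Compound 1, `CCC[C@@H](OC(C)=O)C1=C(Br)/C(=C/Br)OC1=O`: in a functional assay on ZR-75-1 cells (Homo sapiens) for cytotoxicity (on this read-out lower numbers stand for an effect already at smaller amounts and higher numbers for an effect only at larger amounts of compound), compound 1 gives 1.6 ug/mL.
Compound 2, `CCCCCCC(=O)C(Br)=C(Br)Br`: in this assay compound 2 reaches only a limit, > 20 ug/mL.
Compound 3, `CCC[C@@H](OC(C)=O)C1=C(Br)[C@@](OC)(C(Br)Br)OC1=O`: in this assay compound 3 gives 2.8 ug/mL.

Among the numbers shown, compound 1 holds the lowest, with compound 3 nearest; the two sit within the scatter of each other, so no order between them can be read. The value of compound 2 is a limit of the assay and not a number (the limit of > 20 ug/mL in this assay, at which 1 of the 3 values shown sits).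

Compound 4, `CCCCC1=C(Br)/C(=C/Br)OC1=O`, keeps the core of compound 1 and differs in one place: hydrogen in place of acetoxy on a saturated chain carbon bound to a double-bonded ring carbon and a saturated chain carbon. For the measured compounds named here, no measured pair shows what this change does, so any expectation rests on compound 1 alone. Going by the values given here, the step from compound 1 to compound 4 is expected to be modest and toward a higher number, a 2.5-fold higher number from compound 1 to compound 4 (0.40 log units; beyond the scatter), with no measured step to anchor its size. Compound 4 is therefore estimated at 4 ug/mL, within a range from 1.5 ug/mL to 12 ug/mL.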

Compound 4, concentration for half-maximal effect: 10.2 ug/mL
For compound 4 the middle estimate is 2.6-fold (0.41 log units) below the measured one; measured number inside the range.
By their numbers in this assay, from the lowest: compounds 1 and 3 (each within the scatter of the next); then compound 4. At a limit, above all of these: compound 2.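

For the compounds shown here, the step gives the first measured reading of this position: in this assay, hydrogen in place of acetoxy on a saturated chain carbon bound to a double-bonded ring carbon and a saturated chain carbon brings a 6.4-fold higher number from compound 1 to compound 4 (0.80 log units; beyond the scatter) and lies beyond the usual scatter. The acetoxy therefore matters to the read-out on this core, yet it is not required for a measurable effect, since compound 4 still gives 10.2 ug/mL. Nothing measured here bears on why the number moves in this direction.

Going by these compounds, it stays open whether the acetoxy as a whole matters or only the oxygen on that carbon, which a hydroxyl or a longer ester such as butanoyloxy in the same place could separate. On these data alone, it also stays open whether the same change would bring a step of similar size on the core of compound 3.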